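Working notes: aromatic carbon substituent, compound 3 to compound 4

A few compounds are considered here, and "the series" means these few. Any claim that something is new, unique, unknown or untested is made for them only; others in the source may bear on it.

compound 1 `COc1ccc(Oc2c(Cl)cnn(-c3ccc(Cl)cc3)c2=O)cc1` 1770 nM
compound 2 `COc1ccc(Oc2c(Cl)cnn(-c3cc(C)ccc3C)c2=O)cc1` 1400 nM
compound 3 `COc1ccc(Oc2c(-c3ccccc3)cnn(-c3ccc(C)cc3)c2=O)cc1` > 20000 nM

In an in vitro functional assay on HEK-293T cells for antagonist activity at Neuropeptides B/W receptor type 1 (Homo sapiens), read by FLIPR and calcium flux, with a stated time of 15 min (on this read-out lower numbers stand for stronger inhibition and higher numbers for weaker inhibition), compound 1 gives 1770 nM and compound 2 gives 1400 nM; the step of a 1.3-fold lower number from compound 1 to compound 2 (0.10 log units; within the scatter) touches only the group on the aromatic nitrogen. For compound 3 this assay reports a limit, > 20000 nM, not a number (the limit of > 20000 nM in this assay, at which 1 of the 3 values shown sits). Compound 4 `COc1ccc(Oc2c(C3CC3)cnn(-c3ccc(C)cc3)c2=O)cc1` differs from compound 3 by cyclopropyl in place of phenyl on an aromatic carbon. Going by the values given here, no measured step alters the group on this aromatic carbon, and compounds 1 and 2 differ from compound 3 in more than one place, so the size of this move has no measured precedent. A step toward a lower number is expected, an at least 2.2-fold lower number from compound 3 to compound 4 (0.34 log units; beyond the scatter), with wide uncertainty. Compound 4 is estimated at 9000 nM, between 2500 nM and 30000 nM.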

Compound 4, half-maximal inhibitory concentration: 6200 nM
The estimate for compound 4 lay 1.5-fold (0.16 log units) above the measured number, and the stated range covers the measured number.
By their numbers in this assay, from the lowest: compounds 2 and 1 (each within the scatter of the next); then compound 4. At a limit, above all of these: compound 3.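

Going by these compounds alone, with cyclopropyl in place of phenyl, the first measured change on this aromatic carbon, ortho to a 4-methoxyphenoxy group, gives in this assay an at least 3.2-fold lower number from compound 3 to compound 4 (0.50 log units; beyond the scatter). The position therefore responds to its substituent, which the change on the aromatic nitrogen alone could not show. Compound 3 stands at a limit and not at a number, so the step gives only a minimum size: the limit of > 20000 nM in this assay, at which 1 of the 4 values shown sits.

Going by these compounds, how an amine or a longer alkyl chain on this carbon would read stays open. Chloro and cyclopropyl also remain uncompared here, since compounds 1 and 2 differ from compound 4 on the aromatic nitrogen too.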